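The source may hold more compounds than are shown below. What is called first, only, known or untested is meant among the compounds shown, and "the series" means these compounds.

Measured so far in a functional assay on Ehrlich cells (Mus musculus) for cytotoxicity, read by trypan blue exclusion, with a stated time of 2 h, tested at 100 ug/mL; on this read-out higher numbers stand for a stronger effect at the one concentration tested and lower numbers for a weaker effect:

compound 1 `N#CC1=C(NC(=O)C2CC2)N(c2ccc(S(N)(=O)=O)cc2)C2=C(C(=O)CCC2)C1c1ccc(Cl)cc1Cl`: 60%
compound 2 `NC1=C(C(=O)O)C(c2ccc(Cl)cc2Cl)C2=C(CCCC2=O)N1c1ccc(S(N)(=O)=O)cc1`: 60%
compound 3 `CN(C)c1ccc(/C=C/C=N/C2=C(C#N)C(c3ccc(Cl)cc3Cl)C3=C(CCCC3=O)N2c2ccc(S(N)(=O)=O)cc2)cc1`: 20%

Compound 1 and compound 2 are level at the digits given, a difference inside the usual scatter, so no order between the two is read. Compound 3 lies well below both, a gap beyond the scatter. Compound 1 therefore stands at the upper end of the three numbers together with compound 2, and furthest from compound 3.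

The next compound, compound 4 `CC(=O)CC(=O)NC1=C(C#N)C(c2ccc(Cl)cc2Cl)C2=C(CCCC2=O)N1c1ccc(S(N)(=O)=O)cc1`, keeps the shared core of compound 1 and alters only the amide substituent: 2-oxopropyl in place of cyclopropyl on a carbonyl carbon. The amide-type nitrogen and the carbonyl remain; only the group on the carbonyl carbon is exchanged.

For the measured compounds named here, no step between two measured compounds covers this kind of exchange, so nothing on the series itself indicates the size or direction. Compound 1 and compound 2 show that two quite different substituents at this side of the core give the same read-out in this assay, and compound 3 shows that a change there can also lower it. On that basis the step of a number 8 percentage points lower from compound 1 to compound 4 (within the scatter) is expected to be small, at most a modest drop and possibly none beyond the scatter. Compound 4 is estimated at 52%, within 30% to 72%.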

Compound 4, a percentage reported as activity, at one concentration (the size of the read-out at that concentration, not a potency): 80%
The estimate for compound 4 lay 28 percentage points below the measured number; measured number outside the range, above it.
By their numbers in this assay, from the lowest: compound 3; then compounds 1 and 2 (each within the scatter of the next); then compound 4.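

In this assay, for the compounds shown here, the exchange of cyclopropyl for 2-oxopropyl on a carbonyl carbon gives a number 20 percentage points higher from compound 1 to compound 4 (beyond the scatter) and so provides the first readable step at this place. With the amide-type nitrogen and the carbonyl kept, the read-out here responds to the group on the carbonyl carbon alone, and it does not fall when the three-membered ring is replaced by an open chain carrying one hydrogen-bond acceptor. No measurement on these compounds accounts for the rise.

Going by these compounds alone, the single step leaves open whether the rise goes with the loss of the ring or with the oxygen of 2-oxopropyl, a question that a plain butyl chain on the same carbonyl carbon would address, while an amine or a carboxylic acid in that place would test how far the change can be taken. Going by these compounds, the read-out also stands at one concentration, so whether the step would carry over to a difference in potency remains open.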